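From a tert-Butyl Chain to a Quinolinylmethyl Group

The compounds below may be only part of what the source reports. "The series", "measured", "known", "first", "only" and "open" are said of these compounds alone.

Of the compounds shown here, three sharing one core have been measured in a functional assay on CHOK cells for antagonist activity at growth hormone secretagogue receptor type 1 (Homo sapiens), read by calcium flux; on this read-out lower numbers stand for stronger inhibition and higher numbers for weaker inhibition. Compound 1 `Nc1nc(N)c(-c2ccc(NCc3ccnc(Cl)c3)cc2)c(COCc2ccccc2)n1` gives 3.6 nM. Compound 2 `Nc1nc(N)c(-c2ccc(NCc3csc(Cl)c3)cc2)c(COCc2ccccc2)n1` gives 170 nM. Compound 3 `CC(C)(C)CNc1ccc(-c2c(N)nc(N)nc2COCc2ccccc2)cc1` gives 700 nM, the highest of the three numbers; its nearest neighbour is compound 2, and compound 1 lies furthest from it.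

Compound 4 `Nc1nc(N)c(-c2ccc(NCc3cnc4ccccc4c3)cc2)c(COCc2ccccc2)n1` has not yet been measured. It differs from compound 3 in one place: quinolin-3-yl in place of tert-butyl on a saturated chain carbon bound to a nitrogen on an aromatic ring.

Going by the values given here, two measured steps bear on this change, since each, read in reverse, swaps the tert-butyl of compound 3 for an aromatic ring at the same place. The step of a 190-fold higher number from compound 1 to compound 3 (2.29 log units; beyond the scatter) and the step of a 4.1-fold higher number from compound 2 to compound 3 (0.61 log units; beyond the scatter) both show the tert-butyl with the higher number and the aromatic replacement with the lower one, the first of them by a large margin. The quinolin-3-yl entering compound 4, like the ring of compound 1, carries a ring nitrogen counted as one hydrogen-bond acceptor. Compound 4 is therefore expected to show a 47-fold lower number from compound 3 to compound 4 (1.67 log units; beyond the scatter) in this assay, a lower number beyond the scatter and closer to the larger of the two measured steps. The estimate for compound 4 in this assay is 15 nM, with a range from 3 nM to 80 nM.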

Compound 4, half-maximal inhibitory concentration: 780 nM
For compound 4 the middle estimate is 52-fold (1.72 log units) below the measured one; measured number above the stated range.
By their numbers in this assay, from the lowest: compound 1; then compound 2; then compounds 3 and 4 (each within the scatter of the next).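

In this assay, putting quinolin-3-yl where tert-butyl stood gives a step within the scatter (a 1.1-fold higher number from compound 3 to compound 4 (0.05 log units; within the scatter)), so an aromatic group with a ring nitrogen at this place does not by itself bring the low number seen for compound 1. Going by these compounds alone, the aromatic groups themselves now spread widely, with quinolin-3-yl separated from 2-chloropyridin-4-yl (a 220-fold higher number from compound 1 to compound 4 (2.34 log units; beyond the scatter)) and, less far, from 5-chlorothiophen-3-yl (a 4.6-fold higher number from compound 2 to compound 4 (0.66 log units; beyond the scatter)), and compound 4 goes against the pattern of the earlier compounds, in which each aromatic group stood lower than tert-butyl. No measured evidence at hand accounts for this result.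

The compounds shown leave open whether the low number of compound 1 depends on the chlorine or on the ring that carries it, a question that plain pyridin-4-yl and 2-chlorophenyl at this place would separate. They also leave open how a group such as an amine, a carboxylic acid or a longer chain would read at the same place.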